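An Amide-to-Thioester Swap at a Low Starting Number

This account rests on a few compounds, and the source may have more. Where it says the series, first, only, none or still open, it means among the compounds named here.

Among the compounds with values here, compound 1 `CCNC(=O)C1=C(C)NC(=O)NC1c1ccco1` gives 1% in an assay on membranes from HEK293 cells for displacement of a labelled ligand from adenosine receptor A2b (Homo sapiens), read by scintillation counting, with a stated time of 30 min, tested at 1 uM (on this read-out higher numbers stand for more inhibition at the one concentration tested (going by the name of the read-out) and lower numbers for less inhibition), the lowest of the two numbers known here. Its partner compound 2 `CCNC(=O)C1=C(C)NC(=O)NC1c1ccoc1` gives 2% in this assay, and the step of a number 1 percentage points higher from compound 1 to compound 2 (within the scatter) stays within the scatter. Compound 3 `CCSC(=O)C1=C(C)NC(=O)NC1c1ccco1` differs from compound 1 by ethylsulfanyl in place of ethylamino on a carbonyl carbon. Within the data shown here, no measured step touches the carbonyl carbon, so nothing measured bears directly on this change, and both known values sit near the floor of the read-out. Compound 3 is therefore expected to show no step beyond the scatter, a number 1 percentage points higher from compound 1 to compound 3 (within the scatter). The estimate for compound 3 in this assay is 2%, between -8% and 14%.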

Compound 3, a percentage reported as inhibition, at one concentration (the size of the read-out at that concentration, not a potency): 29%
Compound 3: middle estimate off by 27 percentage points, on the low side; measured number above the stated range.
By their numbers in this assay, from the lowest: compounds 1 and 2 (each within the scatter of the next); then compound 3.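

With ethylsulfanyl in place of ethylamino on a carbonyl carbon, this assay shows a number 28 percentage points higher from compound 1 to compound 3 (beyond the scatter) and so this carbonyl position, unlike the furan-3-yl for furan-2-yl swap, moves the read-out. The swap removes the hydrogen-bond donor and brings in sulfur, and the compounds shown do not separate these two differences. Nothing measured here accounts for the rise.

On these data alone, what an ethoxy group or a longer alkylsulfanyl chain would give on this carbonyl carbon remains open. So does whether the same swap carries over to the furan-3-yl partner, compound 2.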